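Glucagon receptor series: pendant ring, hydroxy to amino

This account rests on a few compounds, and the source may have more. Where it says the series, first, only, none or still open, it means among the compounds named here.

Compound 1 `CCCCCc1c(C(C)C)nc(C(C)C)c(CO)c1-c1cccc(O)c1` carries a 3-hydroxyphenyl on the shared core. Among the compounds with values here, in an assay on CHO cells for inhibition of Glucagon receptor (Homo sapiens) (a higher number here means a weaker inhibitor, a lower number a stronger inhibitor), compound 1 gives 6000 nM, the highest of the two numbers measured so far. Compound 2 `CCCCCc1c(C(C)C)nc(C(C)C)c(CO)c1-c1ccccc1O` carries a 2-hydroxyphenyl in its place, and in this assay compound 2 gives 500 nM. Within the data shown here, the step of a 12-fold lower number from compound 1 to compound 2 (1.08 log units; beyond the scatter) is the only measured step, and it is large.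

Compound 3 `CCCCCc1c(C(C)C)nc(C(C)C)c(CO)c1-c1ccccc1N` is not yet measured. Against compound 1 the change is 2-aminophenyl in place of 3-hydroxyphenyl on an aromatic carbon. Among the measured compounds shown here, this shares with the step to compound 2 the shift from a 3-hydroxyphenyl to a ring substituted at the 2-position, but the hydroxy becomes an amino, and for that exchange no measured step exists. The bearing of a 12-fold lower number from compound 1 to compound 2 (1.08 log units; beyond the scatter) therefore points to a lower number, while its full size cannot be assumed to carry over. A drop beyond the scatter is expected, with the step of a 5.0-fold lower number from compound 1 to compound 3 (0.70 log units; beyond the scatter) estimated as the likely outcome. For compound 3 the estimated value is 1200 nM, expected to fall between 300 nM and 5000 nM.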

Compound 3, half-maximal inhibitory concentration: 2300 nM
The estimate for compound 3 lay 1.9-fold (0.28 log units) below the measured number, and the stated range covers the measured number.
By their numbers in this assay, from the lowest: compound 2; then compound 3; then compound 1.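

Exchanging hydroxy for amino on the same pendant ring gives a 4.6-fold higher number from compound 2 to compound 3 (0.66 log units; beyond the scatter) in this assay, so at this place on the shared core the identity of the ring substituent counts, and not only where it stands on the ring. The step of a 2.6-fold lower number from compound 1 to compound 3 (0.42 log units; beyond the scatter) runs the same way as the step from the 3-hydroxyphenyl to the 2-hydroxyphenyl but is smaller, and compound 2 remains the strongest inhibitor of the three, even though the 2-aminophenyl and the 3-hydroxyphenyl do not differ in their counts of heavy atoms, hydrogen-bond donors or hydrogen-bond acceptors. Nothing available here accounts for the gap between the hydroxy and the amino compound.

The compounds shown leave open what a 3-aminophenyl would give, and such a compound would separate the shift of the substituent around the ring from the exchange of hydroxy for amino. Also open, from the compounds shown here alone, is how an unsubstituted phenyl, a 2-methoxyphenyl or a 2-carboxyphenyl would compare on the same core, and so whether a hydroxy or amino group on this ring is needed at all.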